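A few compounds are considered here, and "the series" means these few. Any claim that something is new, unique, unknown or untested is made for them only; others in the source may bear on it.

Compound 1 `CCCSc1ncccc1C(=O)NC1CCCCC1` and compound 2 `CCCSc1c(C(=O)NC2CCCCC2)cnn1C` share a core that carries a propylsulfanyl group. In an ADME assay on cells (Hepatocyte, Rattus norvegicus) for metabolic stability (on this read-out lower numbers stand for slow clearance and higher numbers for fast clearance), compound 1 gives 284 uL/min, while compound 2 gives 120 uL/min, the lower of the two numbers, and the gap between them lies beyond the scatter. Compound 3 `CCCSc1c(C(=O)NC2CCCCC2)cnn1-c1cccc(C(=O)O)c1` differs from compound 2 by 3-carboxyphenyl in place of methyl on an aromatic nitrogen. Among the compounds with values here, no measured pair shows this change, so its effect rests on expectation alone. Compound 3 is expected to clear more slowly than compound 2, with an expected step of a 2.2-fold lower number from compound 2 to compound 3 (0.34 log units; beyond the scatter). In this assay compound 3 is estimated at 55 uL/min, with a range from 18 uL/min to 170 uL/min.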

Compound 3, intrinsic clearance in a liver preparation (reported as CLH), per the amount of preparation that the assay uses in the Hepatocyte assay: 17 uL/min
Estimate against measurement, compound 3: 3.2-fold (0.51 log units) above, outside the stated range (below it).
By their numbers in the Hepatocyte assay, from the lowest: compound 3; then compound 2; then compound 1.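

With 3-carboxyphenyl in place of methyl on the aromatic nitrogen, the Hepatocyte assay shows a 7.1-fold lower number from compound 2 to compound 3 (0.85 log units; beyond the scatter), so this position accepts a much larger group while clearance falls. In a physicochemical assay for lipophilicity, using the shake flask method, at pH 7.4 (on this read-out lower numbers stand for lower lipophilicity and higher numbers for higher lipophilicity), compound 2 gives 3 and compound 3 gives 0.7. The slower clearance may be due to the lower lipophilicity that comes with this change: the measured distribution coefficient of compound 2, 3, and of compound 3, 0.7, a number 2.30 log units lower (beyond the scatter)

The compounds shown do not separate the effect of the phenyl ring from that of the carboxylic acid; a plain phenyl on this nitrogen would tell them apart. As far as these compounds go, whether a primary amide could replace the carboxylic acid also stays open.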